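Trading a Carboxy Group for a Methoxyethyl Amide

The source may report more compounds than this note shows. Statements on the series, on what has been measured and on what is new or still open speak of the compounds shown alone.

Compound 1 `Cc1cc(C(=O)O)ccc1-c1c(N)c(C(=O)c2ccc(F)cc2F)cc[n+]1[O-]`: > 1000 ug/mL
Compound 2 `Cc1cccc(C)c1-c1c(N)c(C(=O)c2ccc(F)cc2F)cc[n+]1[O-]`: 69 ug/mL

In a physicochemical assay for solubility, at pH 7.4 (a higher number here means a more soluble compound, a lower number a less soluble compound), compound 1 reaches only a limit of the assay, > 1000 ug/mL, which is the limit of > 1000 ug/mL in this assay, at which 1 of the 2 values shown sits. Compound 2 gives 69 ug/mL in this assay. Compound 3 `COCCNC(=O)c1ccc(-c2c(N)c(C(=O)c3ccc(F)cc3F)cc[n+]2[O-])c(C)c1` differs from compound 1 by (2-methoxyethyl)amino in place of hydroxy on a carbonyl carbon. Going by the values given here, no measured pair carries this change, so the step must be judged afresh. The expected step of an at least 6.6-fold lower number from compound 1 to compound 3 (0.82 log units; beyond the scatter) is a fall beyond the scatter. Compound 3 is estimated at 150 ug/mL, between 40 ug/mL and 600 ug/mL.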

Compound 3, solubility: 46 ug/mL
For compound 3 the middle estimate is 3.3-fold (0.51 log units) above the measured one, within the range that was stated.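

Read in this assay the change from carboxy to (2-methoxyethyl)carbamoyl gives an at least 21-fold lower number from compound 1 to compound 3 (1.33 log units; beyond the scatter) and this is the first step seen at this place. The number therefore responds strongly to what sits on this carbonyl carbon. Compound 1 stands at a limit of the assay, so the step has a lower bound and no exact size: the limit of > 1000 ug/mL in this assay, at which 1 of the 3 values shown sits.

The compounds shown leave open whether a shorter chain or a longer chain on the amide nitrogen would change the number. Nor do they show what a chain ending in an amine or a carboxylic acid would give.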